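Compound 1 and an isopropyl in place of methyl

This account rests on a few compounds, and the source may have more. Where it says the series, first, only, none or still open, it means among the compounds named here.

Compound 1 `CC(=O)N[C@@H](C)/C=C/c1ccc(Oc2ccc3nc(C)sc3c2Cl)nc1`: 75%
Compound 2 `CC(=O)N[C@@H](C)/C=C/c1ccc(Oc2cc3sc(C)nc3cc2Cl)nc1`: 83%

In an ADME assay on microsomes from liver (Rattus norvegicus) for metabolic stability, with a stated time of 30 min (a lower number here means that less of the compound is left, a higher number that more of the compound is left), compound 1 stands at 75% and compound 2 at 83%, two values within the usual scatter of each other. Compound 3 `CC(=O)N[C@@H](C)/C=C/c1ccc(Oc2ccc3nc(C(C)C)sc3c2Cl)nc1` departs from compound 1 at a single place: isopropyl in place of methyl on an aromatic carbon. It carries isopropyl in place of methyl on an aromatic carbon, next to the ring nitrogen and next to the ring sulfur. Among the measured compounds shown here, no measured pair here differs in one place only, so the data offer no step to scale from, and the expectation rests on the structural change alone. A fall in this assay somewhat beyond the scatter is expected, with less of the compound left. The estimated step is a number 13 percentage points lower from compound 1 to compound 3 (beyond the scatter). The expected value for compound 3 is 62%, with an estimated range of 40% to 80%.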

Compound 3, percent of the compound remaining: 52%
Beside the measured number, compound 3's estimate is 10 percentage points above it; low and high end bracket the measured number.
By their numbers in this assay, from the lowest: compound 3; then compounds 1 and 2 (each within the scatter of the next).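

Among the compounds shown here, replacing methyl with isopropyl on this aromatic carbon of the five-membered ring gives the only step that can be read in this assay: a number 23 percentage points lower from compound 1 to compound 3 (beyond the scatter). This shows that the read-out responds to a change at this position, and that here the larger alkyl group goes with less of the compound left. Nothing available bears on what lies behind this fall.

A single step cannot show whether the fall tracks the size of the group or is particular to isopropyl, and an ethyl, a cyclopropyl or a methoxy group on the same carbon would bear on that question. The compounds shown also leave open whether isopropyl in place of methyl would give a similar step on the core of compound 2.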